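This account rests on a few compounds, and the source may have more. Where it says the series, first, only, none or still open, it means among the compounds named here.

Compound 1, with the structure `Cc1ncn2c(=O)[nH]c(=S)[nH]c12`, and compound 2, with the structure `Cc1nc(C)n2c(=O)[nH]c(=S)[nH]c12`, share one core; the difference between them is methyl in place of hydrogen on an aromatic carbon. In a functional assay on CCRF-CEM cells (Homo sapiens) for cytotoxicity (a higher number here means that more compound is tolerated, a lower number that less compound is tolerated), compound 1 gives 786000 nM, and compound 2 gives 526000 nM, so that the step is a 1.5-fold lower number from compound 1 to compound 2 (0.17 log units; within the scatter). Compound 3, with the structure `Cc1ncn2c(S)ncnc12`, is built on another core; how the core of compound 3 differs from the core of compound 1 is not broken down here. In this assay compound 3 gives 789000 nM, a value within the usual scatter of that of compound 1. Compound 4, with the structure `Cc1nc(C)n2c(S)ncnc12`, has not been measured yet. It differs from compound 3 by methyl in place of hydrogen on an aromatic carbon, which is the same change as the one from compound 1 to compound 2; among these compounds the change occurs in two pairs. Because the earlier step was a 1.5-fold lower number from compound 1 to compound 2 (0.17 log units; within the scatter), a step of similar size is expected here, a 1.3-fold lower number from compound 3 to compound 4 (0.12 log units; within the scatter). For compound 4 the expected value in this assay is 600000 nM, with a range from 300000 nM to 1200000 nM.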

Compound 4, half-maximal cytotoxic concentration: > 694000 nM
Compound 4 was reported as a limit; the forecaster's own chance of this, stated with the estimate: 15%; middle value at least 1.1-fold (0.06 log units) away from the limit.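

In this assay, for the compounds shown here, compound 4 is reported as the limit > 694000 nM and not as a number, so no step from compound 3 to compound 4 can be read. The compounds shown leave open whether methyl in place of hydrogen on an aromatic carbon gives a step of similar size on the core of compound 3 and on the core of compound 1.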